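Triazole to oxadiazolone on the branched carbon: compound 4

The source may hold more compounds than are shown below. What is called first, only, known or untested is meant among the compounds shown, and "the series" means these compounds.

Compound 1, `CC(C)C(c1ccc(-c2ccc3cccc(F)c3c2)[nH]c1=O)N1CCCCS1(=O)=O`, gives 122 nM in a functional assay on CHO cells for antagonist activity at prostaglandin E2 receptor EP3 subtype (Homo sapiens), read by cAMP accumulation; a lower number here means a stronger inhibitor, a higher number a weaker inhibitor.
Compound 2, `CCn1ncc2c(F)cc(-c3ccc(C(CC)(CC)c4nnc(C)[nH]4)c(=O)[nH]3)cc21`, gives 90 nM in this assay.
Compound 3, `CC(C)C(c1nnc[nH]1)c1ccc(-c2ccc3cccc(F)c3c2)[nH]c1=O`, gives 21 nM in this assay.

Compound 3 has the lowest number of the three, so it is the strongest inhibitor among them: its gap to compound 2 and its gap to compound 1 are each beyond the usual scatter. Among the measured compounds shown here, the one single-point step among the measured compounds is a 5.8-fold lower number from compound 1 to compound 3 (0.76 log units; beyond the scatter), which shows that the five-membered ring with three hetero atoms on the branched carbon serves better than the larger six-membered ring it replaced.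

Compound 4, `CC(C)C(c1noc(=O)[nH]1)c1ccc(-c2ccc3cccc(F)c3c2)[nH]c1=O`, differs from compound 3 in exactly that position: a group of 6 heavy atoms (2 carbon, 2 nitrogen, 2 oxygen; one five-membered aromatic ring with 3 hetero atoms) in place of a group of 5 heavy atoms (2 carbon, 3 nitrogen; one five-membered aromatic ring with 3 hetero atoms), on a saturated chain carbon bound to an aromatic carbon and a saturated chain carbon. For the measured compounds named here, no measured pair covers this particular swap of one small aromatic ring for another, so the earlier step only says that a small ring at this position is compatible with strong inhibition. Going by the values given here, with no direct precedent, the expectation is a modest rise at most, a 1.7-fold higher number from compound 3 to compound 4 (0.22 log units; within the scatter), staying within or near the scatter. Compound 4 is therefore estimated at 35 nM in this assay, with a range from 10 nM to 120 nM.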

Compound 4, half-maximal inhibitory concentration: 41 nM
For compound 4 the middle estimate is 1.2-fold (0.07 log units) below the measured one; the range from low to high includes it.
By their numbers in this assay, from the lowest: compounds 3 and 4 (each within the scatter of the next); then compounds 2 and 1 (each within the scatter of the next).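

Swapping the 4H-1,2,4-triazol-3-yl group for the oxadiazolone ring gives a 2.0-fold higher number from compound 3 to compound 4 (0.29 log units; within the scatter), so in this assay these two five-membered aromatic rings cannot be told apart at this saturated chain carbon. The advantage over the six-membered non-aromatic ring of compound 1 also appears with the second ring, as a 3.0-fold lower number from compound 1 to compound 4 (0.47 log units; beyond the scatter), which shows that it does not depend on the triazole alone. Among these three compounds, then, both five-membered aromatic rings with 3 hetero atoms give lower numbers than the six-membered non-aromatic ring, although nothing shown here explains this result.

On these data alone, it remains open whether the ring itself is needed, or whether a carboxylic acid or an amine on the same carbon would give a similar number in this assay. Compound 2 differs from these compounds in more than one place, so it cannot show whether the same ring swap would behave the same way on a different core or with two ethyl groups on this carbon.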